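Dropping a Methoxy Group from an Inactive Seizure Candidate

This account rests on a few compounds, and the source may have more. Where it says the series, first, only, none or still open, it means among the compounds named here.

Measured so far:
compound 1, `COc1cccc(N2CCN(C(=O)C(C)N3C(=O)CCC3=O)CC2)c1`, gives 0% in a functional assay on the whole organism (strain Swiss) with Mus musculus as the target, in the maximal electroshock model, with a stated time of 2 h, at a dose of 300 mg/kg by the intraperitoneal route; on this read-out lower numbers stand for a weaker effect and higher numbers for a stronger effect at the one dose given.
compound 2, `COCC(C(=O)N1CCN(c2cccc(C(F)(F)F)c2)CC1)N1C(=O)CCC1=O`, gives 100% in this assay.

Compound 1 stands at the bottom of the two numbers measured: no effect at all, while compound 2, which differs from it in more than one place, lies higher, well beyond the scatter. Those two values show only that the series can span the whole range; they do not say which part of compound 2 carries its effect.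

Compound 3, `CC(C(=O)N1CCN(c2ccccc2)CC1)N1C(=O)CCC1=O`, is compound 1 with one change: hydrogen in place of methoxy on an aromatic carbon. Nothing measured yet tells how this assay responds to that change, so the step from compound 1 to compound 3 is expected to be small, if anything a slight rise, and quite possibly none beyond the scatter; the estimated step is a number 15 percentage points higher from compound 1 to compound 3 (beyond the scatter). Compound 3 is estimated at 15%, with a likely range from 0% to 60%.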

Compound 3, a percentage reported as activity, at one dose (the size of the read-out at that dose, not a potency): 0%
Compound 3: middle estimate off by 15 percentage points, on the high side; low and high end bracket the measured number.
By their numbers in this assay, from the lowest: compounds 1 and 3 (each within the scatter of the next); then compound 2.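

In this assay, hydrogen in place of methoxy on this aromatic carbon gives no change at the digits printed from compound 1 to compound 3 (within the scatter), so the 3-methoxyphenyl to phenyl change alone does not bring out an effect at the one dose given. Since both compounds sit at the bottom of the read-out, the result cannot show whether this change would lower an effect in a compound that had one to lose. No measurement shown explains this outcome.

On these data alone, it remains open whether a different group on the same aromatic carbon, such as a chlorine atom, an amine or a carboxylic acid, would give a measurable effect on the core of compound 3. The compounds shown also leave unresolved whether trifluoromethyl on this ring would give an effect on that core without any other change.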